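Sulfonyl aryl swap in the bradykinin B1 antagonist series

This account rests on a few compounds, and the source may have more. Where it says the series, first, only, none or still open, it means among the compounds named here.

Compound 1 `COc1ccc(S(=O)(=O)N(C)CCOCC(=O)N(C)Cc2ccc(C3=NCCN3)cc2)c(C)c1` is the reference point of the set. In a functional assay on Umbilical vein for antagonist activity at B1 bradykinin receptor (Homo sapiens), using Schild analysis, with a stated time of 30 min (on this read-out lower numbers stand for lower potency and higher numbers for higher potency (the scale is a negative logarithm)), compound 1 gives 8.6. Two other members carry the same sulfonamide-ether-amide linker with different amide ends: compound 3 `COc1cc(C)c(S(=O)(=O)N(C)CCOCC(=O)N2CCN(C3CCN(C4CC4)CC3)CC2)c(C)c1` gives 8.5 in this assay, a number that sits within the usual scatter of that for compound 1, so the two cannot be ranked against each other; compound 2 `COc1cc(C)c(S(=O)(=O)N(C)CCOCC(=O)N2CCC(C(C)(C)CN(C)C)CC2)c(C)c1` gives 7.5, which lies beyond the scatter below compound 1. Among the compounds with values here, none of these three pairs differs in a single place, so no step between measured compounds is available to calibrate the change considered here.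

Compound 4 `CN(Cc1ccc(C2=NCCN2)cc1)C(=O)COCCN(C)S(=O)(=O)c1c(F)cccc1F` keeps the whole amide end and linker of compound 1 and alters only the aryl group on the sulfonyl: 2,6-difluorophenyl in place of 4-methoxy-2-methylphenyl on a sulfonyl sulfur. The set holds no comparison in which this part of the molecule has been varied, so the direction and size of the step rest on general expectation only. The working estimate is a modest loss that may still fall within the scatter, expressed as a number 0.60 log units lower from compound 1 to compound 4 (beyond the scatter). On this basis compound 4 is expected to give 8 in this assay, with a plausible range from 7.2 to 8.7.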

Compound 4, negative logarithm of the antagonist equilibrium constant: 7.6
Compound 4: the middle estimate sits 0.40 log units above what was measured, within the range that was stated.
By their numbers in this assay, from the lowest: compounds 2 and 4 (each within the scatter of the next); then compounds 3 and 1 (each within the scatter of the next).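

The aryl group on the sulfonyl sulfur now has its first direct reading in the series. With the amide end and linker of compound 1 held constant, 2,6-difluorophenyl in place of 4-methoxy-2-methylphenyl gives a number 1.00 log units lower from compound 1 to compound 4 (beyond the scatter) in this assay, so potency at this position depends on which aryl group is present. No available evidence bears on the origin of this step.

The change removes the methoxy and methyl groups and introduces two fluorines in a single step, so the compounds shown leave open which of these differences carries the loss. Simple phenyl, 4-methoxyphenyl, 2-methylphenyl and 2,6-dichlorophenyl on the same amide end and linker would separate these contributions, while it also remains open whether the step would carry over to the amide ends of compound 2 and compound 3.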